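Trifluoromethyl for methyl on the aryl ring of compound 3

The source may report more compounds than this note shows. Statements on the series, on what has been measured and on what is new or still open speak of the compounds shown alone.

Of the compounds shown here, three sharing one core have been tested in a functional assay on HT-29 cells (Homo sapiens) for antiproliferative activity, read by MTT assay, with a stated time of 48 h; on this read-out lower numbers stand for stronger inhibition of growth and higher numbers for weaker inhibition of growth. Compound 1 `S=C(Nc1ccccc1)N1N=C(c2ccc(Cl)cc2)CC1c1ccc2c(c1)OCCO2` gives 187000 nM. Compound 2 `S=C(Nc1ccccc1)N1N=C(c2ccc(Br)cc2)CC1c1ccc2c(c1)OCCO2` gives 2580 nM, and compound 3 `Cc1ccc(C2=NN(C(=S)Nc3ccccc3)C(c3ccc4c(c3)OCCO4)C2)cc1` gives 19500 nM. Compound 3 therefore stands second of the three: the step of a 7.6-fold higher number from compound 2 to compound 3 (0.88 log units; beyond the scatter) separates it from the lowest number, while the step of a 9.6-fold lower number from compound 1 to compound 3 (0.98 log units; beyond the scatter) separates it from the highest. The remaining step, a 72-fold lower number from compound 1 to compound 2 (1.86 log units; beyond the scatter), shows how strongly this assay responds to a single exchange at the same aromatic carbon.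

Compound 4 `FC(F)(F)c1ccc(C2=NN(C(=S)Nc3ccccc3)C(c3ccc4c(c3)OCCO4)C2)cc1` differs from compound 3 by one change: trifluoromethyl in place of methyl on an aromatic carbon. For the measured compounds named here, no measured step involves a trifluoromethyl group, so the three steps among compounds 1, 2 and 3 bear on the question only as a gauge of how much one substituent at this carbon can move the number. Those moves were modest to large and ran in both directions, so a sizeable shift is plausible while its direction is not settled by the data.

On balance compound 4 is expected to give an estimated 8000 nM, within a range of 1500 nM to 50000 nM, which corresponds to an expected step of a 2.4-fold lower number from compound 3 to compound 4 (0.39 log units; beyond the scatter).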

Compound 4, concentration for 50% growth inhibition: 97500 nM
Estimate against measurement, compound 4: 12-fold (1.09 log units) below, and the stated range ends below it.
By their numbers in this assay, from the lowest: compound 2; then compound 3; then compounds 4 and 1 (each within the scatter of the next).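

In this assay, for the compounds shown here, the step of a 5.0-fold higher number from compound 3 to compound 4 (0.70 log units; beyond the scatter) settles a direction that the earlier compounds could not: at this aromatic carbon, trifluoromethyl goes with weaker inhibition of growth than methyl. The step of a 38-fold higher number from compound 2 to compound 4 (1.58 log units; beyond the scatter) puts trifluoromethyl far from bromo, so compound 2 remains the most potent of the four, with all its steps beyond the scatter, while the step of a 1.9-fold lower number from compound 1 to compound 4 (0.28 log units; within the scatter) lies within the scatter and does not separate trifluoromethyl from chloro. Nothing given alongside these numbers bears on why the four substituents fall in this arrangement.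

The compounds shown leave open how an amine, a methoxy group or a carboxylic acid at this carbon would compare with bromo, and whether a longer chain such as ethyl or propyl would stay close to methyl or move away from it. They also leave open whether bromo would keep its place among these groups if the phenyl group on the thiourea carried a substituent of its own.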